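Cytotoxicity notes: from compound 2 to compound 4

The compounds below may be only part of what the source reports. "The series", "measured", "known", "first", "only" and "open" are said of these compounds alone.

Measured compounds:
compound 1, `c1ccc(Cn2cncc2CNc2cccc(-c3ccccc3)c2)cc1`: > 750 nM, a limit
compound 2, `c1ccc(-c2ccc(Cn3cncc3CNc3cccc(-c4ccccc4)c3)cc2)cc1`: 10000 nM
compound 3, `COC(=O)c1ccc(NCc2cncn2Cc2ccc(OC)cc2)cc1-c1ccccc1`: "not determined" (no result reported)

Among the compounds with values here, in a toxicity assay on NIH3T3 cells (Mus musculus) for cytotoxicity, read by resazurin assay (a lower number here means that less compound is needed, a higher number that more compound is needed for the effect), compound 2 gives 10000 nM, the only single number. For compound 1 the reading > 750 nM is a limit of this assay and not a number. For compound 3 no result was reported, "not determined" (no result reported). Within the data shown here, the one pair that differs in a single place, with phenyl in place of hydrogen on an aromatic carbon, gives the step that the limit leaves unreadable from compound 1 to compound 2, whose size is hidden by the limit of > 750 nM in this assay, at which 1 of the 3 values shown sits.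

Compound 4, `N#Cc1ccc(NCc2cncn2Cc2ccc(-c3ccccc3)cc2)cc1-c1ccccc1`, differs from compound 2 by cyano in place of hydrogen on an aromatic carbon. Among the measured compounds shown here, no measured step in this assay involves a cyano group, and the only step available is unreadable, so nothing in the numbers points to a change in either direction. The working expectation is therefore no step beyond the usual scatter, with the estimated step of no change at the digits printed from compound 2 to compound 4 (within the scatter). Compound 4 is estimated at 10000 nM in this assay, with a range from 4000 nM to 25000 nM; a limit reading, as seen for compound 1, remains possible.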

Compound 4, half-maximal effective concentration: > 1000 nM
Compound 4 was reported as a limit; the forecaster's own chance of this, stated with the estimate: 30%; the middle value lies beyond the limit too.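

In this assay compound 4 gives > 1000 nM, which is a limit and not a number. The change from compound 2 to compound 4 therefore cannot be read as a step: the limit of > 1000 nM in this assay, at which 1 of the 4 values shown sits.

The compounds shown leave open whether cyano in place of hydrogen on this aromatic carbon changes the cytotoxicity reading at all, and in which direction.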